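From 4-Fluorophenyl to 3-Iodophenyl on a Shared Core

A few compounds are considered here, and "the series" means these few. Any claim that something is new, unique, unknown or untested is made for them only; others in the source may bear on it.

Compound 1 `Cc1ccc(-c2nnc(C3=C(Cl)c4cc(C)c(C)cc4CCC3)o2)cc1` and compound 2 `Cc1cc2c(cc1C)C(Cl)=C(c1nnc(-c3ccc(F)cc3)o1)CCC2` have both been measured in a functional assay on MDA-MB-231 cells (Homo sapiens) for antiproliferative activity, read by sulforhodamine B assay, with a stated time of 48 h; on this read-out lower numbers stand for stronger inhibition of growth and higher numbers for weaker inhibition of growth. In this assay, within the data shown here, compound 1 gives 1760 nM and compound 2 gives 1400 nM, so compound 2 stands within the scatter of the only other measured compound. The next structure, compound 3 `Cc1cc2c(cc1C)C(Cl)=C(c1nnc(-c3cccc(I)c3)o1)CCC2`, has 3-iodophenyl in place of 4-fluorophenyl on an aromatic carbon. Among the measured compounds shown here, the only measured step that bears on this change is a 1.3-fold lower number from compound 1 to compound 2 (0.10 log units; within the scatter), with fluoro in place of methyl on an aromatic carbon. For the measured compounds named here, that step stays within the scatter, but no measured compound carries iodine, so it is only a loose guide. No shift beyond the scatter is therefore expected in this assay, and the expected change is a 1.1-fold higher number from compound 2 to compound 3 (0.03 log units; within the scatter). The estimate for compound 3 is 1500 nM, within an expected range from 600 nM to 3800 nM.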

Compound 3, concentration for 50% growth inhibition: 2670 nM
The estimate for compound 3 lay 1.8-fold (0.25 log units) below the measured number; low and high end bracket the measured number.
By their numbers in this assay, from the lowest: compounds 2, 1 and 3 (each within the scatter of the next).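

In this assay, among these compounds, the first iodine-bearing group at this position gives a 1.9-fold higher number from compound 2 to compound 3 (0.28 log units; within the scatter) when 3-iodophenyl replaces 4-fluorophenyl and a 1.5-fold higher number from compound 1 to compound 3 (0.18 log units; within the scatter) when it replaces 4-methylphenyl. Across these three compounds, a change in both the substituent and its place on the phenyl ring has therefore produced no step beyond the scatter at this position on the shared core. No measured evidence bears on why the numbers fall as they do.

The halogen and its place on the phenyl ring change together between compound 2 and compound 3, so their separate contributions cannot be told apart. On these data alone, whether an amine or a carboxylic acid on this phenyl ring would move the number beyond the scatter also remains open.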